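The source may report more compounds than this note shows. Statements on the series, on what has been measured and on what is new or still open speak of the compounds shown alone.

The series rests on a shared core, first seen in compound 1 `COc1cc2c(cc1N1CCN[C@H](C)C1)N(S(=O)(=O)c1ccc(-c3ccccn3)s1)CC2`. In a functional assay with growth hormone secretagogue receptor type 1 (Homo sapiens) as the target (on this read-out lower numbers stand for smaller maximal responses and higher numbers for larger maximal responses), compound 1 gives 1. Compound 2 `COc1cc2c(cc1N1C[C@H](C)NC(C)(C)C1)N(S(=O)(=O)c1ccc(-c3ccccn3)s1)CC2` carries a larger saturated ring in place of the smaller one on the same aromatic carbon, and in this assay compound 2 gives 1. That step, no change at the digits printed from compound 1 to compound 2 (within the scatter), lies within the scatter, so compound 2 stands level with compound 1 at the digits shown; the two values give no spread to speak of. Compound 3 `COc1cc2c(cc1N1CCNC(C)(C)C1)N(S(=O)(=O)c1ccc(-c3ccccn3)s1)CC2` remains to be measured in this assay. Its difference from compound 2 is hydrogen in place of methyl on a saturated ring carbon. Going by the values given here, the one step at hand, no change at the digits printed from compound 1 to compound 2 (within the scatter), altered that same saturated ring more extensively and moved the read-out not at all. Compound 3 is therefore expected to show no step beyond the scatter, no change at the digits printed from compound 2 to compound 3 (within the scatter). Compound 3 is estimated at 1, with a range of 0.85 to 1.05.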

Compound 3, intrinsic activity: the largest response reached, as a fraction of the reference agonist's: 0.9
The estimate for compound 3 lay 0.10 above the measured number; the measured number falls inside the stated range.
By their numbers in this assay, from the lowest: compounds 3, 1 and 2 (each within the scatter of the next).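

In this assay, hydrogen in place of methyl on this saturated ring carbon gives a number 0.10 lower from compound 2 to compound 3 (within the scatter), so the methyl at this position can be lost without a step beyond the scatter. The other new comparison, 3,3-dimethylpiperazin-1-yl in place of 3-methylpiperazin-1-yl on the aromatic carbon, gives a number 0.10 lower from compound 1 to compound 3 (within the scatter), which keeps all three ring patterns shown here within the scatter of one another on this read-out. Nothing given here explains why these changes leave the maximal response within the scatter.

From the compounds shown here alone, what a hydroxymethyl group, a phenyl ring or a carboxylic acid on this ring carbon would do remains open. So does the effect of an acetyl group on the ring nitrogen.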